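Swapping the aryl group on a cyclopentenone silyl ether

This account rests on a few compounds, and the source may have more. Where it says the series, first, only, none or still open, it means among the compounds named here.

Two compounds share a core and differ only in one aryl group. Compound 1 `COc1ccc(OC)c(C2=C(c3cc(OC)c(OC)c(OC)c3)C(=O)CC2O[SiH2]C(C)(C)C)c1` gives 6.5 ug/mL in an ADME assay on ECV-304 cells (Homo sapiens) for cytotoxicity, read by MTT assay, with a stated time of 72 h; a higher number here means a weaker inhibitor, a lower number a stronger inhibitor. Within the data shown here, compound 2 `COc1cc(C2=C(c3cc(C)c(OC)c(C)c3)C(O[SiH2]C(C)(C)C)CC2=O)cc(OC)c1OC` gives 15 ug/mL in this assay, the higher of the two numbers, and the one step measured so far, a 2.3-fold higher number from compound 1 to compound 2 (0.36 log units; beyond the scatter), moved the number upward. Compound 3 `COc1ccc(C2=C(c3cc(OC)c(OC)c(OC)c3)C(=O)CC2O[SiH2]C(C)(C)C)cc1O` is not yet measured. It differs from compound 2 in the same place (3-hydroxy-4-methoxyphenyl in place of 4-methoxy-3,5-dimethylphenyl on a double-bonded ring carbon). Among the measured compounds shown here, the only step that bears on this change is the one from compound 1 to compound 2, and it went in the direction of a weaker inhibitor when the methyl-bearing aryl group entered; with that group now leaving, a step back toward the lower number is expected, though the incoming group is not the one seen in compound 1, so the size is uncertain. Compound 3 is therefore estimated at 7 ug/mL, with a range of 3 ug/mL to 20 ug/mL, which means an expected step of a 2.1-fold lower number from compound 2 to compound 3 (0.33 log units; beyond the scatter).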

Compound 3, half-maximal inhibitory concentration: 30 ug/mL
For compound 3 the middle estimate is 4.3-fold (0.63 log units) below the measured one, and the stated range ends below it.
By their numbers in this assay, from the lowest: compound 1; then compounds 2 and 3 (each within the scatter of the next).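

Within this assay, replacing 4-methoxy-3,5-dimethylphenyl with 3-hydroxy-4-methoxyphenyl on the double-bonded ring carbon gives a 2.0-fold higher number from compound 2 to compound 3 (0.30 log units; within the scatter), so these two groups cannot be told apart here. The comparison with 2,5-dimethoxyphenyl gives a 4.6-fold higher number from compound 1 to compound 3 (0.66 log units; beyond the scatter), which leaves compound 1 as the only one of the three that stands apart, with the lowest number, and nothing shown gives a reason for this.

The compounds shown leave open whether a quite different substituent on this aryl ring, such as an amine or a carboxylic acid, would shift the number further. Because the aryl groups differ in more than one substituent, they also leave open which substituent accounts for the gap from compound 1.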